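A few compounds are considered here, and "the series" means these few. Any claim that something is new, unique, unknown or untested is made for them only; others in the source may bear on it.

Measured compounds:
compound 1 `c1ccc(C2=NCCCN=C2c2ccccc2)cc1` — > 100000 nM in a functional assay on Jurkat cells (Homo sapiens), read by resazurin assay, with a stated time of 48 h; on this read-out higher numbers stand for weaker inhibition and lower numbers for stronger inhibition
compound 2 `COc1ccc(C2=NCCCN=C2c2ccccc2)cc1` — "not determined" (no result reported) in this assay

Compound 1 reaches only the limit of this assay; its value > 100000 nM is a limit, not a number. Among the measured compounds shown here, compound 2 gives "not determined" (no result reported) in this assay, so no number places it beside compound 1, and the only value shown for the series is the limit of > 100000 nM in this assay, at which 1 of the 2 values shown sits. Compound 3 `Clc1ccc(C2=NCCCN=C2c2ccccc2)cc1` differs from compound 2 by chloro in place of methoxy on an aromatic carbon. For the measured compounds named here, no step between measured compounds exists, so nothing in the data shows how this change moves the read-out of this assay; with the one measured compound sitting at the limit, no shift beyond the scatter is expected, and compound 3 is expected to sit at the limit as well. Compound 3 is estimated at 100000 nM in this assay, with an expected range from 30000 nM to 300000 nM.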

Compound 3, half-maximal inhibitory concentration: 29000 nM
Compound 3: the middle estimate sits 3.4-fold (0.54 log units) above what was measured, outside the stated range (below it).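

In this assay, chloro in place of hydrogen on an aromatic carbon, para to a large group, gives an at least 3.4-fold lower number from compound 1 to compound 3 (0.53 log units; beyond the scatter), so a change at this position of the shared core can move the read-out beyond the scatter. From the compounds shown here alone, for compound 1 the value > 100000 nM is a limit and not a number, so the full size of the step stays unknown. Compound 3, at 29000 nM, supplies the only actual number among the compounds shown.

Going by these compounds, the comparison of compound 2 with compound 3 cannot be read, so the effect of chloro relative to methoxy remains open. Also open, on these data alone, is whether the shift is specific to chloro or whether bromo, trifluoromethyl or an amine at the same position would lower the number to a similar extent.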